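The source may report more compounds than this note shows. Statements on the series, on what has been measured and on what is new or still open speak of the compounds shown alone.

Compound 3 `CN(Cc1cccc(Br)c1)C(=O)c1cc2c(Cc3ccccc3)n[nH]c2cc1O` gives 7100 nM in a functional assay on A2780 cells (Homo sapiens) for antiproliferative activity, read by resazurin assay, with a stated time of 72 h; a higher number here means a weaker inhibitor, a lower number a stronger inhibitor. Compound 2 `CN(Cc1cccc(Cl)c1)C(=O)c1cc2c(Cc3ccccc3)n[nH]c2cc1O` gives 5300 nM, within the usual scatter of compound 3, so the two cannot be told apart. Compound 1 `CCCN(C)C(=O)c1cc2c(Cc3ccccc3)n[nH]c2cc1O` reads > 10000 nM, which is a limit of the assay and not a number.

Compound 4 `CN(Cc1ccc(Br)cc1)C(=O)c1cc2c(Cc3ccccc3)n[nH]c2cc1O` has not yet been measured. It has the same atoms as compound 3, joined differently: 4-bromophenyl in place of 3-bromophenyl on a saturated chain carbon bound to an amide-type nitrogen. In words, 4-bromophenyl stands in place of 3-bromophenyl on a saturated chain carbon bound to an amide-type nitrogen.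

For the measured compounds named here, no measured step makes this exact change, so the evidence is only indirect. Bromo in place of chloro on an aromatic carbon gave a 1.3-fold higher number from compound 2 to compound 3 (0.13 log units; within the scatter), which lies within the scatter. Replacing ethyl gave an at least 1.8-fold lower number from compound 1 to compound 2 (0.27 log units; that floor lies within the scatter) and an at least 1.4-fold lower number from compound 1 to compound 3 (0.14 log units; that floor lies within the scatter), and both of those floors also lie within the scatter.

No step beyond the scatter is therefore expected in this assay, and neither direction is favoured. The expected change is a 1.1-fold lower number from compound 3 to compound 4 (0.04 log units; within the scatter). For compound 4 the estimated value is 6500 nM, with an expected range from 3000 nM to 14000 nM.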

Compound 4, half-maximal inhibitory concentration: 2800 nM
Compound 4: middle estimate off by 2.3-fold (0.37 log units), on the high side, outside the stated range (below it).
By their numbers in this assay, from the lowest: compounds 4, 2 and 3 (each within the scatter of the next, the first and the last beyond it). At a limit, above all of these: compound 1.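

In this assay, for the compounds shown here, where the bromine sits on the ring matters, which the earlier compounds could not show: a 2.5-fold lower number from compound 3 to compound 4 (0.40 log units; beyond the scatter), beyond the scatter, while a 1.9-fold lower number from compound 2 to compound 4 (0.28 log units; within the scatter) stays within it. Replacing ethyl also now gives a clear difference, with an at least 3.5-fold lower number from compound 1 to compound 4 (0.55 log units; beyond the scatter), whereas the earlier replacements of ethyl stayed within the scatter at their floors. That step is only a floor, since compound 1 stands at a limit of the assay and not at a number: the limit of > 10000 nM in this assay, at which 1 of the 4 values shown sits.

From the compounds shown here alone, whether this shift depends on bromo itself or would hold for any group on the ring remains open. A plain phenyl, or a methoxy or an amine in place of the bromo in 4-bromophenyl, would help separate the two.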